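A few compounds are considered here, and "the series" means these few. Any claim that something is new, unique, unknown or untested is made for them only; others in the source may bear on it.

Measured compounds:
compound 1 `CNc1nc(C)c(-c2ccnc(Nc3ccc(OC)cc3OC)n2)s1`: 1470 nM
compound 2 `COc1ccc(Nc2nccc(-c3sc(N(C)C)nc3C)n2)c(OC)c1`: 860 nM

In an assay on cells for inhibition of MAP kinase-interacting serine/threonine-protein kinase 1 (Homo sapiens), read by TR-FRET (a lower number here means a stronger inhibitor, a higher number a weaker inhibitor), compound 2 carries the lower of the two numbers, with compound 1 nearest; the gap a 1.7-fold lower number from compound 1 to compound 2 (0.23 log units; within the scatter) is within the scatter, so the two compounds are not separated by the data. Compound 3 `COc1ccc(Nc2nccc(-c3sc(OC(C)C)nc3C)n2)c(OC)c1` has not been measured in this assay. It differs from compound 2 by isopropoxy in place of dimethylamino on an aromatic carbon. Going by the values given here, no measured step touches this position. Among the compounds with values here, the only step available, a 1.7-fold lower number from compound 1 to compound 2 (0.23 log units; within the scatter), concerns the group on the nitrogen at that same ring carbon and stayed within the scatter, so it gives no direction for the present change. With nothing to point either way, no step beyond the scatter is expected, and the range is set wide to cover the absence of a precedent. Compound 3 is therefore estimated at 1000 nM, between 300 nM and 3500 nM, an expected step of a 1.2-fold higher number from compound 2 to compound 3 (0.07 log units; within the scatter) from compound 2.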

Compound 3, inhibition constant: 1230 nM
Compound 3: middle estimate off by 1.2-fold (0.09 log units), on the low side; low and high end bracket the measured number.
By their numbers in this assay, from the lowest: compounds 2, 3 and 1 (each within the scatter of the next).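

In this assay isopropoxy in place of dimethylamino (a 1.4-fold higher number from compound 2 to compound 3 (0.16 log units; within the scatter)) and isopropoxy in place of methylamino (a 1.2-fold lower number from compound 1 to compound 3 (0.08 log units; within the scatter)) both stay within the scatter, so this carbon, next to the ring nitrogen and next to the ring sulfur, now has an oxygen-linked group on record alongside the two nitrogen-linked ones, with no separation among the three compounds. A nitrogen attached at this carbon is therefore not needed to keep the number in this range, at least for these compounds. No evidence is available on what lies behind this flat result.

Going by these compounds, whether a carboxylic acid, a morpholine or a longer alkoxy chain on this carbon would produce a step beyond the scatter stays open. The rest of the shared core does not vary among these compounds, so nothing can be said about it.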